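Swapping phenyl for benzofuran on an inactive nucleoside

The source may hold more compounds than are shown below. What is called first, only, known or untested is meant among the compounds shown, and "the series" means these compounds.

Compound 2 (`Nc1nc2c(c(-c3ccccc3)cn2[C@@H]2O[C@H](CO)[C@@H](O)[C@H]2O)c(=O)[nH]1`) gives > 20000 nM in a functional assay on K562 cells (Homo sapiens), read by MTT assay, with a stated time of 72 h (on this read-out higher numbers stand for weaker inhibition and lower numbers for stronger inhibition), as its result, and this is a limit of the assay, not a number. Compound 1 (`O=c1[nH]cnc2c1c(-c1cc3ccccc3o1)cn2[C@@H]1O[C@H](CO)[C@@H](O)[C@H]1O`) gives > 20000 nM in this assay as its result, again only a limit. Compound 2 therefore has no exact potency to start from, and all the data so far amount to the limit of > 20000 nM in this assay, at which 2 of the 2 values shown sit, with no number to compare.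

Compound 3 (`Nc1nc2c(c(-c3cc4ccccc4o3)cn2[C@@H]2O[C@H](CO)[C@@H](O)[C@H]2O)c(=O)[nH]1`) keeps the rest of compound 2 and changes one group: 1-benzofuran-2-yl in place of phenyl on an aromatic carbon. Compound 1 already carries 1-benzofuran-2-yl, and compound 1 still shows > 20000 nM as its limit, which gives little reason to expect a large gain in this assay here.

The expected change is a number no higher from compound 2 to compound 3 (the limit leaves the size open) and none beyond the scatter is expected, with any movement more likely toward stronger inhibition. The estimate for compound 3 is 20000 nM with an expected range from 6000 nM to 25000 nM and a good chance of ending at a limit of the assay.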

Compound 3, half-maximal inhibitory concentration: > 20000 nM
Compound 3: no number, only a limit; the forecaster's own chance of this, stated with the estimate: 75%; the middle value lies on the limit itself.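

In this assay compound 3 gives > 20000 nM, which is a limit of the assay and not a number. Its steps from compound 1 and from compound 2 cannot be read, because the results all end at one limit: the limit of > 20000 nM in this assay, at which 3 of the 3 values shown sit.

The compounds shown leave open whether 1-benzofuran-2-yl in place of phenyl, or amino in place of hydrogen, changes inhibition in this assay at all.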